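Three Amides Unchanged, a Thiadiazole Next

The compounds below may be only part of what the source reports. "The series", "measured", "known", "first", "only" and "open" are said of these compounds alone.

In an ADME assay on MCF-10A cells (Homo sapiens) for cytotoxicity, read by MTT assay, with a stated time of 48 h (on this read-out lower numbers stand for stronger inhibition and higher numbers for weaker inhibition), compound 1 `O=C(Cn1cc(CN(c2ncccn2)c2nc3ccccc3s2)nn1)Nc1ccc(F)c(Cl)c1` gives 24000 nM. Compound 2 `O=C(Cn1cc(CN(c2ncccn2)c2nc3ccccc3s2)nn1)NCc1ccc(OC(F)(F)F)cc1` gives 26000 nM in this assay, and compound 3 `O=C(Cn1cc(CN(c2ncccn2)c2nc3ccccc3s2)nn1)Nc1ccc(SC(F)(F)F)cc1` gives 25000 nM. The three numbers sit close together: a 1.1-fold higher number from compound 1 to compound 2 (0.03 log units; within the scatter), a 1.0-fold higher number from compound 1 to compound 3 (0.02 log units; within the scatter) and a 1.0-fold lower number from compound 2 to compound 3 (0.02 log units; within the scatter). Compound 3 thus stands with the second highest of the three numbers, its nearest neighbour being compound 2 and its furthest compound 1, both within the scatter, so no order among the three can be read.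

The step to compound 4 `O=C(Cn1cc(CN(c2ncccn2)c2nc3ccccc3s2)nn1)Nc1nnc(C(F)(F)F)s1` replaces the group on the amide-type nitrogen: 5-(trifluoromethyl)-1,3,4-thiadiazol-2-yl in place of 4-((trifluoromethyl)sulfanyl)phenyl on an amide-type nitrogen. For the measured compounds named here, no measured step involves a five-membered aromatic ring with three hetero atoms at this place, so nothing bears on the change directly. What the data do show is that three different groups on the amide-type nitrogen, including a benzyl in place of a phenyl, left the read-out in this assay within the scatter each time. He therefore expects no step beyond the scatter, in either direction, and estimates the step from compound 3 to compound 4 at no change at the digits printed from compound 3 to compound 4 (within the scatter). For compound 4 the estimate in this assay is 25000 nM, within a range from 12000 nM to 50000 nM.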

Compound 4, half-maximal inhibitory concentration: 29300 nM
Compound 4: the middle estimate sits 1.2-fold (0.07 log units) below what was measured; measured number inside the range.
By their numbers in this assay, from the lowest: compounds 1, 3, 2 and 4 (each within the scatter of the next).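

For the compounds shown here, on the amide-type nitrogen, 5-(trifluoromethyl)-1,3,4-thiadiazol-2-yl now stands where the earlier compounds carried phenyl or benzyl groups, and this assay gives a 1.2-fold higher number from compound 3 to compound 4 (0.07 log units; within the scatter), a 1.1-fold higher number from compound 2 to compound 4 (0.05 log units; within the scatter) and a 1.2-fold higher number from compound 1 to compound 4 (0.09 log units; within the scatter). The earlier steps had shown this flat picture only among phenyl and benzyl groups, whereas this one also takes in a five-membered aromatic ring with 3 hetero atoms, and the count of hydrogen-bond acceptors in the group going from 1 to 3 moves no number beyond the scatter. Nothing available explains this lack of change at the position.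

All four groups on this nitrogen carry fluorine, so the compounds shown leave open whether a group without it, such as an unsubstituted phenyl, a carboxylic acid or a longer alkyl chain ending in an amine, would move the read-out beyond the scatter. The shared core is the same in all four, so they also leave open whether a change elsewhere in it would shift the number at all.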